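A Phenyl in Place of Methyl: What to Expect

This account rests on a few compounds, and the source may have more. Where it says the series, first, only, none or still open, it means among the compounds named here.

Among the measured compounds shown here, compound 1 `Cc1ccc(NC(=O)CCc2cccc3c2B(O)OC3)cc1` is one of two compounds so far measured in a functional assay on HCT-116 cells (Homo sapiens) for antiproliferative activity, read by MTT assay, with a stated time of 72 h; on this read-out lower numbers stand for stronger inhibition and higher numbers for weaker inhibition. In this assay compound 1 gives 4500 nM, the highest of the two numbers shown; its nearest neighbour is compound 2 `O=C(CCc1cccc2c1B(O)OC2)Nc1cccc(Br)c1`, which in this assay gives 1400 nM. For the measured compounds named here, the single measured step, a 3.2-fold lower number from compound 1 to compound 2 (0.51 log units; beyond the scatter), replaces the group on the amide-type nitrogen and is modest though beyond the scatter. Compound 3 `O=C(CCc1cccc2c1B(O)OC2)Nc1ccc(-c2ccccc2)cc1` has not yet been measured. It differs from compound 1 in one place: phenyl in place of methyl on an aromatic carbon. Going by the values given here, no measured step covers this exact change; the step from compound 1 to compound 2 shows only that altering the group attached to the amide-type nitrogen can move the number in this assay by a modest amount, and there it moved down. On that basis a step of similar or smaller size is expected, more likely downward than upward, though a step beyond the scatter is not assured. For compound 3 the estimate in this assay is 2500 nM, with a range from 800 nM to 8000 nM, which is expected to correspond to a 1.8-fold lower number from compound 1 to compound 3 (0.26 log units; within the scatter).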

Compound 3, half-maximal inhibitory concentration: 13000 nM
Estimate against measurement, compound 3: 5.2-fold (0.72 log units) below; the measured number lies above the stated range.
By their numbers in this assay, from the lowest: compound 2; then compound 1; then compound 3.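

In this assay, among the compounds shown here, putting phenyl in place of methyl on this aromatic carbon, para to a large group, gives a 2.9-fold higher number from compound 1 to compound 3 (0.46 log units; beyond the scatter) and so moves the number upward, whereas the only earlier step, a 3.2-fold lower number from compound 1 to compound 2 (0.51 log units; beyond the scatter), had moved it downward. Changes on this aromatic ring of the shared core can therefore shift the number in either direction, and the earlier compounds alone did not show this. The change from methyl to phenyl adds one six-membered aromatic ring of carbon only and no hydrogen-bond donors or acceptors, yet it still takes the number beyond the scatter, though nothing in the data at hand accounts for the rise.

With only methyl and phenyl compared at this position, the compounds shown leave open whether the number climbs steadily with the size of the group or whether phenyl is a special case, which an ethyl or a tert-butyl group there could help to separate. They also leave open how this position would respond to an amine, a carboxylic acid or a methoxy group.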